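Swapping ethoxy for aminoamino on a carbonyl carbon

The source may report more compounds than this note shows. Statements on the series, on what has been measured and on what is new or still open speak of the compounds shown alone.

- Compound 1 `COc1ccc(C(=NNC(=O)NNC(=O)NCCCC(C)Nc2cc(OC)cc3cccnc23)c2ccc(OC)cc2)cc1`: 1000 nM
- Compound 2 `CCOC(=O)NC(c1ccccc1)c1ccc(Cl)cc1`: > 100000 nM (a limit)

In a functional assay on MCF7 cells (Homo sapiens) for inhibition, read by MTT assay, with a stated time of 4 days (on this read-out lower numbers stand for stronger inhibition and higher numbers for weaker inhibition), compound 1 gives 1000 nM, a true measured number. Compound 2 has no such number, and its entry of > 100000 nM is a limit. The position of compound 2 is therefore known only as a limit of the test: the limit of > 100000 nM in this assay, at which 1 of the 2 values shown sits.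

The next compound, compound 3 `NNC(=O)NC(c1ccccc1)c1ccc(Cl)cc1`, differs from compound 2 in one place, with aminoamino in place of ethoxy on a carbonyl carbon. In longer terms, ethoxycarbonyl becomes aminocarbamoyl.

Among the measured compounds shown here, no measured pair of compounds shows this change, so any forecast for this assay is uncertain. A modest move towards lower numbers is expected, although compound 3 may well end at a limit too. The estimated step is an at least 2.0-fold lower number from compound 2 to compound 3 (0.30 log units; that floor lies within the scatter). Compound 3 is expected at about 50000 nM, with an estimated range of 12000 nM to 100000 nM.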

Compound 3, half-maximal inhibitory concentration: >= 100000 nM
Compound 3 was reported as a limit (the forecaster's own chance of this, stated with the estimate: 45%); middle value at least 2.0-fold (0.30 log units) from the limit.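

In this assay compound 2 gives > 100000 nM, which is a limit. Compound 3 gives >= 100000 nM, also a limit, so no step can be read between these two compounds. The compounds shown leave open whether aminoamino in place of ethoxy on a carbonyl carbon changes the inhibition at all, and in which direction.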